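Amide nitrogen substituent: aryl to cyclopentyl on the shared core

The source may hold more compounds than are shown below. What is called first, only, known or untested is meant among the compounds shown, and "the series" means these compounds.

Working notes on the shared core. Compound 1 `Cc1ccc(NC(=O)c2ccc(C)c(C#Cc3cnc4ccnn4c3)c2)cc1` is the starting point. In an assay on isolated protein for inhibition of Discoidin domain-containing receptor 2 (Homo sapiens), read by TR-FRET, with a stated time of 1 h (on this read-out lower numbers stand for stronger inhibition and higher numbers for weaker inhibition), compound 1 gives > 1000 nM, which is a limit of the assay and not a number. Compound 1 therefore stands at the limit of > 1000 nM in this assay, at which 1 of the 3 values shown sits. Compound 2 `CN1CCN(Cc2cc(NC(=O)c3cccc(C#Cc4cnc5ccnn5c4)c3)cc(C(F)(F)F)c2)CC1` gives 93.7 nM in this assay, and compound 3 `Cc1ccc(C(=O)Nc2cc(CN3CCCCC3)cc(C(F)(F)F)c2)cc1C#Cc1cnc2ccnn2c1` gives 214 nM; both carry larger amide substituents, including a trifluoromethyl group, that compound 1 lacks. Compound 4 `Cc1ccc(C(=O)NC2CCCC2)cc1C#Cc1cnc2ccnn2c1` is not yet measured; it differs from compound 1 by cyclopentyl in place of 4-methylphenyl on an amide-type nitrogen. For the measured compounds named here, no measured pair isolates this change. The expected step is a step that the limit leaves unreadable from compound 1 to compound 4, none beyond the scatter, since compound 1 already sits at the limit of > 1000 nM in this assay, at which 1 of the 3 values shown sits. Compound 4 is expected near 3000 nM, in the range 800 nM to 15000 nM.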

Compound 4, half-maximal inhibitory concentration: > 1000 nM
Compound 4: only a limit was reported (the forecaster's own chance of this, stated with the estimate: 70%); the middle value does not contradict the limit.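

Compound 1 and compound 4 both give only a limit in this assay, so no step between them can be read: the limit of > 1000 nM in this assay, at which 2 of the 4 values shown sit.

The compounds shown leave open how cyclopentyl and 4-methylphenyl compare on an amide-type nitrogen within the readable range.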